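A few compounds are considered here, and "the series" means these few. Any claim that something is new, unique, unknown or untested is made for them only; others in the source may bear on it.

Measured in a functional assay on MDA-MB-231 cells (Homo sapiens) for antiproliferative activity, read by MTT assay, with a stated time of 72 h; on this read-out higher numbers stand for weaker inhibition and lower numbers for stronger inhibition:
compound 1 `CN1CCN(C(=S)SSC(=S)N2CCN(C)CC2)CC1`: 3000 nM
compound 2 `CCCCSSC(=S)N(CC)CC`: 7400 nM
compound 3 `CCN(CC)C(=S)SSC(C)C`: 960 nM

Compound 2, at 7400 nM, gives the highest number of the three and so is the weakest inhibitor among them in this assay. Compound 1 at 3000 nM and compound 3 at 960 nM both lie lower, by more than the usual scatter.

Not yet measured is compound 4 `CCCCCCSSC(=S)N(CC)CC`, which differs from compound 2 in one place: ethyl in place of hydrogen on a saturated chain carbon, four bonds along the chain from a sulfur.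

Within the data shown here, only one measured step bears on this change, and only indirectly: a 7.7-fold lower number from compound 2 to compound 3 (0.89 log units; beyond the scatter), with isopropyl in place of butyl on a sulfur. It shows that the number in this assay can respond to the group on that sulfur. However, that step replaces the butyl group, whereas compound 4 extends the chain, and no measured step shows what extending it does. From the compounds shown here alone, the direction therefore stays open, and the expectation is a smaller step than that one, quite possibly none beyond the scatter.

The estimated shift is a 1.1-fold lower number from compound 2 to compound 4 (0.06 log units; within the scatter). For compound 4 the expected value is 6500 nM, with an estimated range from 2500 nM to 15000 nM.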

Compound 4, half-maximal inhibitory concentration: > 10000 nM
Compound 4 was reported as a limit; the forecaster's own chance of this, stated with the estimate: 5%; middle value at least 1.5-fold (0.18 log units) from the limit.
By their numbers in this assay, from the lowest: compound 3; then compound 1; then compound 2. At a limit, above all of these: compound 4.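

this assay reports compound 4 only as a limit of the assay, not as a number: the limit of > 10000 nM in this assay, at which 1 of the 4 values shown sits. With ethyl in place of hydrogen on a saturated chain carbon, four bonds along the chain from a sulfur, this gives an at least 1.3-fold higher number from compound 2 to compound 4 (0.13 log units; that floor lies within the scatter), and since that floor lies within the scatter, the limit alone does not establish a real rise. Among these compounds, the earlier compounds showed only that replacing the butyl group could lower the number, in a 7.7-fold lower number from compound 2 to compound 3 (0.89 log units; beyond the scatter), whereas this result is the first reading on extending the chain, and it shows no gain in inhibition from that extension, with compound 4 placed at its limit above the other three values.

From the compounds shown here alone, how far compound 4 truly lies from compound 2 remains open, and so does whether a shorter addition such as methyl at the same carbon would move the number at all. Also open, going by these compounds, is what a polar group on this chain, such as an amine or a carboxylic acid, or a longer chain would do in place of the ethyl.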